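This account rests on a few compounds, and the source may have more. Where it says the series, first, only, none or still open, it means among the compounds named here.

Series notes. Compound 1 `CCc1ccccc1NS(=O)(=O)c1ccc(NC(=O)NCCCCl)cc1` and compound 2 `CCNC(=O)Nc1ccc(S(=O)(=O)Nc2ccccc2C)cc1` share the same sulfonyl-urea core and differ elsewhere. In a functional assay on M21 cells (Homo sapiens) for cytotoxicity, read by sulforhodamine B assay, with a stated time of 48 h (on this read-out higher numbers stand for weaker inhibition and lower numbers for stronger inhibition), compound 1 gives > 200000 nM, which is a limit of the assay and not a number. In this assay compound 2 gives > 200000 nM, again a limit of the assay rather than a measured number. Compound 2 therefore stands at the limit of > 200000 nM in this assay, at which 2 of the 2 values shown sit, and no numerical value places it relative to anything else in the set. Compound 3 `CCNC(=O)Nc1ccc(S(=O)(=O)Nc2ccccc2CC)cc1` is not yet measured. It differs from compound 2 by methyl in place of hydrogen on a saturated chain carbon bound to an aromatic carbon. Among the compounds with values here, no step between measured compounds covers this change, so nothing in the data sets its size or direction; what can be noted is only that compound 1, which also carries the 2-ethylphenyl, sits at the same limit. Expected in this assay is a step that the limit leaves unreadable from compound 2 to compound 3, that is, no step beyond the scatter, with the read-out most probably once more a limit. Compound 3 is estimated at 250000 nM, with a range of 100000 nM to 1000000 nM.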

Compound 3, half-maximal inhibitory concentration: 90000 nM
Estimate against measurement, compound 3: 2.8-fold (0.44 log units) above; measured number outside the range, below it.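

In this assay, compound 3 gives the first read-out in the set that is a number and not a limit. The change from 2-methylphenyl to 2-ethylphenyl, methyl in place of hydrogen on a saturated chain carbon bound to an aromatic carbon, gives an at least 2.2-fold lower number from compound 2 to compound 3 (0.34 log units; beyond the scatter), so this position responds to the addition of 1 carbon. The 2-ethylphenyl alone does not account for the value, since compound 1 carries it too: hydrogen in place of chloromethyl on a saturated chain carbon, two bonds along the chain from an amide-type nitrogen, gives an at least 2.2-fold lower number from compound 1 to compound 3 (0.34 log units; beyond the scatter), and the true size of both steps stays unread, as each starts from a limit: the limit of > 200000 nM in this assay, at which 2 of the 3 values shown sit.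

Still open, going by these compounds, is whether a propyl or isopropyl group in place of the ethyl of the 2-ethylphenyl would carry the step further or reverse it. Also open is what an amine or a carboxylic acid at the far end of the urea chain would do, since the chloromethyl is the only such replacement shown.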